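Hydroxyformamide series: removing the propyl chain from compound 3

A few compounds are considered here, and "the series" means these few. Any claim that something is new, unique, unknown or untested is made for them only; others in the source may bear on it.

Measured so far in an assay on CHO cells for inhibition of bone morphogenetic protein 1 (Homo sapiens), with stated times of 10 min and 60 min; on this read-out lower numbers stand for stronger inhibition and higher numbers for weaker inhibition:
compound 1 `CCCCC[C@@H](C(=O)NCNC(=O)c1ccc(-c2cc(OCC)cc(C(=O)O)c2)o1)[C@@H](CC)N(O)C=O`: < 1 nM
compound 2 `CCCCC[C@H](CN(O)C=O)C(=O)NCNC(=O)c1ccc(-c2ccccc2)o1`: 25 nM
compound 3 `CCC[C@H](CN(O)C=O)C(=O)NCNC(=O)c1cc2cccc(OC)c2o1`: 1250 nM

In this assay compound 1 gives < 1 nM, which is a limit of the assay rather than a number (the limit of < 1 nM in this assay, at which 1 of the 3 values shown sits). Of the two numbers that are known, compound 3 at 1250 nM is the higher; the nearer value is that of compound 2 at 25 nM, and the gap between them is beyond the scatter. Compound 2 and compound 3 differ in more than one place, so their values are only taken side by side, not as one step.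

Compound 4 `COc1cccc2cc(C(=O)NCNC(=O)CCN(O)C=O)oc12` is not yet measured. It differs from compound 3 by hydrogen in place of propyl on a saturated chain carbon bound to a carbonyl carbon and a saturated chain carbon. Within the data shown here, no measured pair shows this change. Loss of the chain is expected to give a step of a 4.0-fold higher number from compound 3 to compound 4 (0.60 log units; beyond the scatter) towards a higher number, beyond the scatter. Compound 4 is estimated at 5000 nM, between 1500 nM and 20000 nM.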

Compound 4, half-maximal inhibitory concentration: 6300 nM
Beside the measured number, compound 4's estimate is 1.3-fold (0.10 log units) below it; measured number inside the range.
By their numbers in this assay, from the lowest: compound 2; then compound 3; then compound 4. At a limit, below all of these: compound 1.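

In this assay, among these compounds, this is the first single-change step at this position, and it is a 5.0-fold higher number from compound 3 to compound 4 (0.70 log units; beyond the scatter); the propyl chain on this core therefore contributes to inhibition, though its size here is modest. The chain is not indispensable to a readable result, since compound 4 still gives 6300 nM with hydrogen on the saturated chain carbon bound to a carbonyl carbon and a saturated chain carbon. Nothing available here bears on why removing the chain gives a step of this size.

One step cannot show whether inhibition follows chain length at this carbon, and a methyl group or a butyl chain there would test it on the core of compound 3. On these data alone, whether an amine at the same carbon would be tolerated also remains open.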